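Butyl in place of propyl on the chloro member of the series

This account rests on a few compounds, and the source may have more. Where it says the series, first, only, none or still open, it means among the compounds named here.

Compound 3 `CCCNC(=O)NS(=O)(=O)c1ccc(-n2nc(-c3ccc(Cl)cc3)ccc2=O)cc1` gives 122% in a functional assay on the whole organism (blood, strain Wistar albino) for inhibition, with Rattus norvegicus as the target, read by colorimetric assay, with stated times of 15 min and 90 min, at a dose of 20 mg/kg by the oral route (a lower number here means less inhibition, a higher number more inhibition at the dose given (going by the name of the read-out)), and stands highest of the three measured compounds. Going by the values given here, compound 1 `CCCCNC(=O)NS(=O)(=O)c1ccc(-n2nc(-c3ccccc3)ccc2=O)cc1` gives 111% and compound 2 `CCCCNC(=O)NS(=O)(=O)c1ccc(-n2nc(-c3ccc(C)cc3)ccc2=O)cc1` gives 109%; the only single-point step measured is a number 2 percentage points lower from compound 1 to compound 2 (within the scatter), a change on the aromatic ring, not on the chain. Compound 4 `CCCCNC(=O)NS(=O)(=O)c1ccc(-n2nc(-c3ccc(Cl)cc3)ccc2=O)cc1` differs from compound 3 by methyl in place of hydrogen on a saturated chain carbon, three bonds along the chain from an amide-type nitrogen, that is, propyl to butyl. Among the compounds with values here, no measured step bears directly on this chain change; compound 1 and compound 2, both butyl-bearing, differ from compound 3 in two places at once, so their gaps to compound 3 cannot be assigned to the chain alone. With the ring substituent of compound 3 kept, the expectation for compound 4 is a step of a number 5 percentage points lower from compound 3 to compound 4 (within the scatter), likely not beyond the scatter. Compound 4 is therefore estimated at 117%, with a range from 103% to 130%.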

Compound 4, a percentage reported as inhibition, in the whole organism at one dose (the size of the read-out at that dose, not a potency): 100%
The estimate for compound 4 lay 17 percentage points above the measured number, and the stated range ends above it.
By their numbers in this assay, from the lowest: compounds 4, 2 and 1 (each within the scatter of the next, the first and the last beyond it); then compound 3.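

In this assay, the chain position now has a measured step: butyl in place of propyl on the chloro member gives a number 22 percentage points lower from compound 3 to compound 4 (beyond the scatter), so a single added methyl at this chain carbon changes the number beyond the scatter. With butyl held fixed, the ring can be read as well: chloro in place of methyl gives a number 9 percentage points lower from compound 2 to compound 4 (within the scatter), while chloro in place of hydrogen gives a number 11 percentage points lower from compound 1 to compound 4 (beyond the scatter), so the high number of compound 3 does not carry over to the butyl chloro member. No measurement at hand offers an explanation for these steps.

Whether the chain step recurs with hydrogen or methyl on the ring remains open, as the series shown has no propyl partner for compound 1 or compound 2. From the compounds shown here alone, how ethyl, a longer chain such as pentyl, or a cyclohexyl group would read at this position is also open.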